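From 2-chlorophenyl to 4-methoxyphenyl on a shared core

The compounds below may be only part of what the source reports. "The series", "measured", "known", "first", "only" and "open" are said of these compounds alone.

In a functional assay on FM3A cells (Mus musculus) for antiproliferative activity (on this read-out higher numbers stand for weaker inhibition and lower numbers for stronger inhibition), compound 1 `COc1cc(C(=O)c2sc(-c3ccccc3)cc2N)cc(OC)c1OC` gives 13 nM, while compound 2 `COc1cc(C(=O)c2sc(-c3ccccc3Cl)cc2N)cc(OC)c1OC` gives 34 nM. Compound 2 thus holds the higher of the two numbers, which here means the weaker inhibition. The next structure, compound 3 `COc1ccc(-c2cc(N)c(C(=O)c3cc(OC)c(OC)c(OC)c3)s2)cc1`, keeps the shared core and changes one group, with 4-methoxyphenyl in place of 2-chlorophenyl on an aromatic carbon. Going by the values given here, the one measured step that bears on this, a 2.6-fold higher number from compound 1 to compound 2 (0.42 log units; beyond the scatter), is modest and beyond the scatter, and it came with chloro in place of hydrogen on an aromatic carbon, so the loss of the chloro in compound 3 points to a lower number. Among the compounds with values here, no measured compound shows what the 4-methoxyphenyl itself does, which leaves real uncertainty. A step of similar or smaller size towards a lower number is therefore expected in this assay. The expected change is a 1.7-fold lower number from compound 2 to compound 3 (0.23 log units; within the scatter). Compound 3 is estimated at 20 nM, with an expected range from 6 nM to 70 nM.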

Compound 3, half-maximal inhibitory concentration: 31 nM
For compound 3 the middle estimate is 1.6-fold (0.19 log units) below the measured one; measured number inside the range.
By their numbers in this assay, from the lowest: compound 1; then compounds 3 and 2 (each within the scatter of the next).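

In this assay, the swap of 2-chlorophenyl for 4-methoxyphenyl comes to a 1.1-fold lower number from compound 2 to compound 3 (0.04 log units; within the scatter), so the two groups cannot be told apart at this position, even though 4-methoxyphenyl brings a hydrogen-bond acceptor that 2-chlorophenyl lacks. Adding methoxy to the plain phenyl ring gives a 2.4-fold higher number from compound 1 to compound 3 (0.38 log units; beyond the scatter), which is a real step, so the weaker inhibition seen with chloro is no longer a lone case: compound 2 and compound 3 both carry higher numbers than compound 1. Taking away the chloro therefore did not by itself restore the number of compound 1, and among these three compounds the plain phenyl ring gives the strongest inhibition.

The two groups differ both in the atoms they add and in the number in their names, so these compounds cannot separate the kind of group from its place on the phenyl ring, and they do not show how an amine or a carboxylic acid on that ring would behave. Nothing measured here explains why these groups give these numbers.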